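Shortening the hydroxamate chain of compound 2

The source may report more compounds than this note shows. Statements on the series, on what has been measured and on what is new or still open speak of the compounds shown alone.

Compound 1 `Nc1ncnc2c1c(-c1cnc3[nH]ccc3c1)nn2CCCCCCCCC(=O)NO` gives 5460 nM
Compound 2 `Nc1nc2cc(-c3nn(CCCCCCCCCC(=O)NO)c4ncnc(N)c34)ccc2o1` gives 23100 nM

Both values come from a functional assay on HCT-116 cells (Homo sapiens) for inhibition, read by MTT assay, with a stated time of 72 h (on this read-out lower numbers stand for stronger inhibition and higher numbers for weaker inhibition), and mark out a narrow starting point. Compound 2 holds the higher of the two numbers (23100 nM), so it is the weaker of the pair. Compound 1 lies lower (5460 nM), and that gap is beyond the scatter.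

The next compound is compound 3 `Nc1nc2cc(-c3nn(CCCCCCC(=O)NO)c4ncnc(N)c34)ccc2o1`. The change is hydroxycarbamoyl in place of 3-(hydroxycarbamoyl)propyl on a saturated chain carbon, six bonds along the chain from an aromatic nitrogen on a saturated chain carbon, six bonds along the chain from an aromatic nitrogen. The shared core and the group on it stay as in compound 2.

Within the data shown here, no measured pair isolates chain length. Compound 2 also differs from compound 1 in the group on the core, so the lower value of compound 1 (5460 nM) gives only weak support for a direction. A move toward stronger inhibition is expected, with a step beyond the scatter, estimated as a 5.8-fold lower number from compound 2 to compound 3 (0.76 log units; beyond the scatter) in this assay with wide uncertainty. Compound 3 is estimated at 4000 nM with an expected range of 800 nM to 20000 nM in this read-out.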

Compound 3, half-maximal inhibitory concentration: 5390 nM
Estimate against measurement, compound 3: 1.3-fold (0.13 log units) below, within the range that was stated.
By their numbers in this assay, from the lowest: compounds 3 and 1 (each within the scatter of the next); then compound 2.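

Chain length can now be read on its own at this position: with the shared core and the group on it held as in compound 2, putting hydroxycarbamoyl in place of 3-(hydroxycarbamoyl)propyl on a saturated chain carbon, six bonds along the chain from an aromatic nitrogen, gives a 4.3-fold lower number from compound 2 to compound 3 (0.63 log units; beyond the scatter) in this assay. The earlier pair could not show this, since compound 1 and compound 2 also differ in the group on the core, whereas this single change shows that the chain alone moves the read-out, with the shorter chain of compound 3 giving the stronger inhibition. This rests on one pair, and nothing measured here accounts for the step.

The compounds shown leave open whether a still shorter chain continues in this direction or whether a chain of intermediate length does better than compound 3, so the pair gives a direction and no optimum. Also open, as far as these compounds go, are whether a carboxylic acid in place of the hydroxamic acid end keeps any of the inhibition, and whether the same shortening holds with the core group of compound 1.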